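Naphthalen-1-yl in place of 4-ethylphenyl on a sulfur

The source may hold more compounds than are shown below. What is called first, only, known or untested is meant among the compounds shown, and "the series" means these compounds.

Of the compounds shown here, two have numbers so far: compound 1 (`COc1ccc(SCc2ccc(/C=C/C(=O)Nc3ccccc3N)cc2)cc1OC`) and compound 2 (`CCc1ccc(SCc2ccc(/C=C/C(=O)Nc3ccccc3N)cc2)cc1`). In a functional assay on A-375 cells (Homo sapiens) for inhibition, read by CCK-8 assay, with a stated time of 72 h, tested at 2 uM (a higher number here means more inhibition of growth at the concentration tested, a lower number less inhibition of growth), compound 1 gives 46%, while compound 2 gives 5.27%, the lower of the two numbers.

The next change leads to compound 3 (`Nc1ccccc1NC(=O)/C=C/c1ccc(CSc2cccc3ccccc23)cc1`), with naphthalen-1-yl in place of 4-ethylphenyl on a sulfur.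

Among the compounds with values here, only one measured step bears on this place: a number 40.7 percentage points lower from compound 1 to compound 2 (beyond the scatter), with 4-ethylphenyl in place of 3,4-dimethoxyphenyl on a sulfur. Within the data shown here, that large step shows that this assay can respond strongly to the group on this sulfur, but no measured compound carries naphthalen-1-yl, so the direction is poorly constrained. Compound 2 at 5.27% leaves little room for a fall, so a modest rise is the more likely outcome, and a return to the level of compound 1 remains possible.

The expected change is a number 12.7 percentage points higher from compound 2 to compound 3 (beyond the scatter), an estimate of moderate size. For compound 3 the estimated value is 18%, with an expected range of 3% to 45%.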

Compound 3, percent growth inhibition at one concentration: 1.55%
The estimate for compound 3 lay 16.5 percentage points above the measured number; the measured number lies below the stated range.
By their numbers in this assay, from the lowest: compounds 3 and 2 (each within the scatter of the next); then compound 1.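

In this assay, naphthalen-1-yl on the sulfur gives a number 3.7 percentage points lower from compound 2 to compound 3 (within the scatter), so the second aromatic ring and the larger carbon count of naphthalen-1-yl make no readable difference from 4-ethylphenyl at this position. Set against the 3,4-dimethoxyphenyl group, the same change gives a number 44.5 percentage points lower from compound 1 to compound 3 (beyond the scatter), which means two different groups made only of carbon and hydrogen now share the low level, while the one oxygen-bearing group among the three stands apart from both. No measurement here accounts for this separation or links it to any property of the groups on the sulfur.

The compounds shown leave open whether the higher number of compound 1 needs both methoxy groups or whether a single methoxy group would hold it, and whether other oxygen- or nitrogen-bearing substituents on the phenyl ring, such as a hydroxyl group, an amine or a carboxylic acid, would match it. Within the data shown here, with only three groups compared at one concentration, they also leave open whether the link between oxygen-bearing groups and higher growth inhibition holds beyond compound 1.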